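A few compounds are considered here, and "the series" means these few. Any claim that something is new, unique, unknown or untested is made for them only; others in the source may bear on it.

Measured compounds:
compound 1, `CC(=O)OC/C(=C\c1ccc(F)cc1)C(=O)c1ccccc1`, 13000 nM
compound 2, `CC(=O)OC/C(=C\c1ccccc1F)C(=O)c1ccccc1`, 19000 nM
compound 3, `CC(=O)OC/C(=C\c1ccc([N+](=O)[O-])cc1)C(=O)c1ccccc1`, 23000 nM

All three were run in a functional assay on WiDr cells (Homo sapiens) for inhibition, read by sulforhodamine B assay, with a stated time of 48 h; on this read-out higher numbers stand for weaker inhibition of growth and lower numbers for stronger inhibition of growth. Compound 1 gives 13000 nM, compound 2 gives 19000 nM and compound 3 gives 23000 nM. The three numbers sit close together: a 1.5-fold higher number from compound 1 to compound 2 (0.16 log units; within the scatter) and a 1.8-fold higher number from compound 1 to compound 3 (0.25 log units; within the scatter), so no ordering among them can be claimed.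

The core of compound 2 differs from that of compound 1 by 2-fluorophenyl in place of 4-fluorophenyl on a double-bonded chain carbon bound to a double-bonded chain carbon. On the core of compound 1 the change nitro in place of fluoro on an aromatic carbon has been measured once; it sits para to a large group. The unmeasured compound 4, `CC(=O)OC/C(=C\c1ccccc1[N+](=O)[O-])C(=O)c1ccccc1`, carries the same kind of change on the core of compound 2, (nitro in place of fluoro on an aromatic carbon), where the place is ortho to a large group rather than para to it.

Expectation for compound 4 in this assay rests on that single earlier step, a 1.8-fold higher number from compound 1 to compound 3 (0.25 log units; within the scatter), which stayed within the scatter. Among the measured compounds shown here, the step from compound 2 to compound 4 is therefore expected to be of similar size, a 1.6-fold higher number from compound 2 to compound 4 (0.20 log units; within the scatter), with added uncertainty because the surroundings of the place are not the same and only one such step has been seen. The estimated value for compound 4 is 30000 nM, with an expected range from 14000 nM to 65000 nM.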

Compound 4, concentration for 50% growth inhibition: 18000 nM
Beside the measured number, compound 4's estimate is 1.7-fold (0.22 log units) above it, within the range that was stated.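

In this assay, nitro in place of fluoro on an aromatic carbon, ortho to a large group, gives a 1.1-fold lower number from compound 2 to compound 4 (0.02 log units; within the scatter), so on this core the swap leaves no readable difference. Set beside the same swap on the core of compound 1, the two steps do not differ: the same change on two cores in this assay, a 1.8-fold higher number (0.25 log units; within the scatter) from compound 1 to compound 3 and a 1.1-fold lower number (0.02 log units; within the scatter) from compound 2 to compound 4, 1.9-fold (0.27 log units) apart, within the scatter of two such steps. This shows that, across these two cores, the change stays within the scatter whichever core carries it; it does not show a fixed size or direction for the change, since both steps are too small to be told from repeat noise, and two steps from a single assay support no rule for the wider series.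

Open, on these data alone, is whether any group on this aromatic ring moves the growth inhibition beyond the scatter, for example an amine or a carboxylic acid at the same aromatic carbon, since nitro and fluoro alone cannot say how far the read-out responds to a change at that place. Also open, as far as these compounds go, is whether a change elsewhere on the shared core, such as a longer chain in place of the acetate, would separate the compounds in a way these small steps do not.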